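Swapping a Branched Chain for an Acetylpiperidinyl Ring

The compounds below may be only part of what the source reports. "The series", "measured", "known", "first", "only" and "open" are said of these compounds alone.

compound 1 `CC(C)c1onc(-c2c(Cl)cccc2Cl)c1COc1ccc(-c2nc3ccc(C(=O)O)cc3n2C)cc1`: 7150 nM
compound 2 `CC(C)c1onc(-c2c(Cl)cccc2Cl)c1COc1ccc(-c2nc3ccc(C(=O)O)cc3n2CC(C)(C)C)cc1`: 861 nM
compound 3 `CC(C)Cn1c(-c2ccc(OCc3c(-c4c(Cl)cccc4Cl)noc3C(C)C)cc2)nc2ccc(C(=O)O)cc21`: 1180 nM

Three compounds share one core and differ only in the group carried on an aromatic nitrogen of that core; all were tested in an assay on HEK-293T cells for antagonist activity at vitamin D3 receptor (Homo sapiens), read by a luciferase reporter, with a stated time of 24 h; a higher number here means a weaker inhibitor, a lower number a stronger inhibitor. Compound 3 stands second highest of the three numbers. Its nearest neighbour is compound 2, with a 1.4-fold higher number from compound 2 to compound 3 (0.14 log units; within the scatter), a gap within the scatter; the far one is compound 1, with a 6.1-fold lower number from compound 1 to compound 3 (0.78 log units; beyond the scatter), a gap beyond it.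

Compound 4 `CC(=O)N1CCC(n2c(-c3ccc(OCc4c(-c5c(Cl)cccc5Cl)noc4C(C)C)cc3)nc3ccc(C(=O)O)cc32)CC1` is compound 3 with a single change: 1-acetylpiperidin-4-yl in place of isobutyl on an aromatic nitrogen. The measured steps that touch this position are an 8.3-fold lower number from compound 1 to compound 2 (0.92 log units; beyond the scatter) and a 6.1-fold lower number from compound 1 to compound 3 (0.78 log units; beyond the scatter), both of which lowered the number when a branched chain replaced hydrogen. Among the compounds with values here, no measured step shows what a ring with a hydrogen-bond acceptor does there, so the expectation must be cautious. Compound 4 is expected to land close to its parent, with a 1.0-fold higher number from compound 3 to compound 4 (0.01 log units; within the scatter), meaning no step beyond the scatter is expected in either direction. The estimate for compound 4 is 1200 nM, within a range from 350 nM to 4000 nM.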

Compound 4, half-maximal inhibitory concentration: > 10000 nM
Compound 4 was reported as a limit; the forecaster's own chance of this, stated with the estimate: 5%; middle value at least 8.3-fold (0.92 log units) away from the limit.
By their numbers in this assay, from the lowest: compounds 2 and 3 (each within the scatter of the next); then compound 1. At a limit, above all of these: compound 4.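

Compound 4 is reported only as a limit, so every step to it is a floor rather than a measured size: the limit of > 10000 nM in this assay, at which 1 of the 4 values shown sits. Even so, the position that took branched chains does not accept every larger group, as 1-acetylpiperidin-4-yl gives an at least 8.4-fold higher number from compound 3 to compound 4 (0.92 log units; beyond the scatter) and an at least 11-fold higher number from compound 2 to compound 4 (1.06 log units; beyond the scatter), which ends the trend of larger groups lowering the number seen with compound 2 and compound 3. Against the much smaller methyl there is an at least 1.3-fold higher number from compound 1 to compound 4 (0.14 log units; that floor lies within the scatter), so whether compound 4 truly stands above compound 1 cannot be read.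

The change brings a ring and an acetyl group at once, and the compounds shown cannot separate the two. A cyclohexyl group, carrying a six-membered ring with no acetyl, or a piperidin-4-yl group with a free amine would help tell them apart.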